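Benzoyl for Cyclopropylcarbonyl on a Methoxy-Bearing Analogue

The compounds below may be only part of what the source reports. "The series", "measured", "known", "first", "only" and "open" are said of these compounds alone.

Three compounds have been measured:
compound 1 `O=C(Nc1nn(C(=O)C2CC2)c2c1CN(C(=O)c1ccccc1)C2)c1ccccc1`, 1240 nM;
compound 2 `O=C(Nc1nn(C(=O)c2ccccc2)c2c1CN(C(=O)c1ccccc1)C2)c1ccccc1`, 1400 nM;
compound 3 `COc1ccc(C(=O)Nc2nn(C(=O)C3CC3)c3c2CN(C(=O)c2ccccc2)C3)cc1`, 5180 nM.

In a functional assay on HCT-116 cells (Homo sapiens) for cytotoxicity, read by sulforhodamine B assay, with a stated time of 48 h (on this read-out higher numbers stand for weaker inhibition and lower numbers for stronger inhibition), compound 1 gives 1240 nM and compound 2 gives 1400 nM. The change between them, (phenyl in place of cyclopropyl on a carbonyl carbon), made a step of a 1.1-fold higher number from compound 1 to compound 2 (0.05 log units; within the scatter). Compound 3 differs from compound 1 by methoxy in place of hydrogen on an aromatic carbon, and that step was a 4.2-fold higher number from compound 1 to compound 3 (0.62 log units; beyond the scatter), leaving compound 3 with the highest number of the three.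

Compound 4 `COc1ccc(C(=O)Nc2nn(C(=O)c3ccccc3)c3c2CN(C(=O)c2ccccc2)C3)cc1` has not been measured. It differs from compound 3 by phenyl in place of cyclopropyl on a carbonyl carbon, the same change that led from compound 1 to compound 2, on a place described in the same words. Because that earlier step was a 1.1-fold higher number from compound 1 to compound 2 (0.05 log units; within the scatter), the step from compound 3 to compound 4 is expected to be of similar size, about a 1.1-fold higher number from compound 3 to compound 4 (0.03 log units; within the scatter). Compound 4 is therefore estimated at 5600 nM, between 2500 nM and 12500 nM.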

Compound 4, half-maximal inhibitory concentration: 31300 nM
The estimate for compound 4 lay 5.6-fold (0.75 log units) below the measured number; the whole stated range lies below it.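

In this assay, phenyl in place of cyclopropyl on a carbonyl carbon gave a 6.0-fold higher number from compound 3 to compound 4 (0.78 log units; beyond the scatter), and methoxy in place of hydrogen on an aromatic carbon gave a 22-fold higher number from compound 2 to compound 4 (1.35 log units; beyond the scatter). The step from cyclopropylcarbonyl to benzoyl did not carry over at the same size from the core of compound 1 to the methoxy-bearing core of compound 3: the same change on two cores in this assay, a 1.1-fold higher number (0.05 log units; within the scatter) from compound 1 to compound 2 and a 6.0-fold higher number (0.78 log units; beyond the scatter) from compound 3 to compound 4, 5.4-fold (0.73 log units) apart, beyond the scatter of two such steps This single pair of cores shows that the size of the step depends on the core, but it does not show why, or how the change would behave on any other core.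

The compounds shown leave open whether a fluorine or a dimethylamino group in place of the methoxy would give the same dependence. They also leave open how an acetyl group or a longer acyl chain would behave in place of the benzoyl.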